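Plasma half-life of an amidine ester: benzyl replaces ethyl

The source may hold more compounds than are shown below. What is called first, only, known or untested is meant among the compounds shown, and "the series" means these compounds.

Measured so far:
Compound 1, `C/C(=C\c1ccc(C(=O)Oc2ccc(C(=N)N)cc2)cc1)C(=O)N(CC(=O)O)C1CCCCC1`, gives > 1 h in an in vitro ADME assay on a cell-free system (plasma) for pharmacokinetics; on this read-out lower numbers stand for a shorter-lived compound and higher numbers for a longer-lived compound.
Compound 2, `CCN(CC(=O)O)C(=O)/C(C)=C/c1ccc(C(=O)Oc2ccc(C(=N)N)cc2)cc1`, gives 1 h in this assay.

The value of compound 1 is a limit of the assay and not a number. Going by the values given here, compound 2 therefore carries the only plain number in this assay; the other value shown is a limit (the limit of > 1 h in this assay, at which 1 of the 2 values shown sits). Among the compounds with values here, the one measured step, a number no higher from compound 1 to compound 2 (the limit leaves the size open), replaces cyclohexyl by ethyl on the amide-type nitrogen, and because one end of it is a limit of > 1 h in this assay, at which 1 of the 2 values shown sits, its size stays open.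

Compound 3, `C/C(=C\c1ccc(C(=O)Oc2ccc(C(=N)N)cc2)cc1)C(=O)N(CC(=O)O)Cc1ccccc1`, differs from compound 2 in one place: phenyl in place of methyl on a saturated chain carbon bound to an amide-type nitrogen. This change sits on the chain carbon bound to the amide-type nitrogen, not on the nitrogen itself, so the measured step speaks only indirectly to it, and its own size cannot be read. Nothing shown points to a change beyond the scatter, so the step of a 1.2-fold higher number from compound 2 to compound 3 (0.08 log units; within the scatter) is expected to stay small. Compound 3 is estimated to give 1.2 h in this assay, within 0.5 h to 3 h.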

Compound 3, half-life: > 1 h
Compound 3 ended at the assay's limit; the forecaster's own chance of this, stated with the estimate: 30%; the middle value does not contradict the limit.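

In this assay compound 3 gives > 1 h, which is a limit of the assay and not a number. Going by these compounds alone, putting phenyl in place of methyl on a saturated chain carbon bound to an amide-type nitrogen gives a number no lower from compound 2 to compound 3 (the limit leaves the size open), so this is the first evidence on a group carrying an aromatic ring at this place, and the read-out does not drop with it. The earlier compounds showed this direction only for cyclohexyl, a ring attached straight to the nitrogen, whereas benzyl reaches the same limit, and neither the size of the new step nor the step between compound 1 and compound 3 can be read: the limit of > 1 h in this assay, at which 2 of the 3 values shown sit.

The compounds shown leave open how long compound 1 and compound 3 actually last in plasma, and so whether benzyl and cyclohexyl differ at all. They also leave open how a butyl chain, or a chain ending in an amine, would behave on the same nitrogen.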